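Allyl Removal on a Sulfur Across Two Inactive Cores

The compounds below may be only part of what the source reports. "The series", "measured", "known", "first", "only" and "open" are said of these compounds alone.

Compound 1 `C=CCSc1nncc2c(CC)ncn12` carries an allylsulfanyl group on one core, and compound 3 `C=CCSc1nncc2cnc(-c3ccccc3)n12` carries the same group on a second core; the difference between the two cores is not broken down here. In a functional assay for inhibition, with Homo sapiens as the target (a lower number here means a stronger inhibitor, a higher number a weaker inhibitor), compound 1 gives only a limit, > 48000 nM. Compound 3 likewise stops at the limit of this assay, > 48000 nM. Compound 2 `CCc1ncn2c(S)nncc12` differs from compound 1 by hydrogen in place of allyl on a sulfur. Compound 2 also reaches only the limit of this assay, > 48000 nM. The step that the two limits leave unreadable from compound 1 to compound 2 therefore cannot be read in either direction. All three values share one limit (the limit of > 48000 nM in this assay, at which 3 of the 3 values shown sit).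

Compound 4 `Sc1nncc2cnc(-c3ccccc3)n12` differs from compound 3 by the same change, (hydrogen in place of allyl on a sulfur). The step that the limit leaves unreadable from compound 3 to compound 4 is expected in this assay to show no measurable gain, because compound 1 and compound 2 both sit at the limit (the limit of > 48000 nM in this assay, at which 3 of the 3 values shown sit). Compound 4 is thus expected to give 70000 nM in this assay, most probably again only a limit, within a range from 20000 nM to 250000 nM.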

Compound 4, half-maximal inhibitory concentration: > 48000 nM
Compound 4 ended at the assay's limit; the forecaster's own chance of this, stated with the estimate: 90%; the middle value is on the limit's open side.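

In this assay compound 4 gives > 48000 nM, which is a limit and not a number. Compound 3 also stands at a limit, so no step can be read between compound 3 and compound 4: the limit of > 48000 nM in this assay, at which 4 of the 4 values shown sit. The compounds shown leave open how strongly any of them inhibits, and whether allylsulfanyl or sulfanyl makes any difference on either core.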